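Piperazine substituent change in a T-cell inhibitor series

The source may report more compounds than this note shows. Statements on the series, on what has been measured and on what is new or still open speak of the compounds shown alone.

Compound 1 `COc1ccc(-c2cnc3nc(N)nc(N4CCN(C(=O)COc5ccccc5)CC4)c3n2)cc1OC` carries the shared core with a piperazine that bears a (phenoxymethyl)carbonyl group. In a functional assay on cells (T-cell, Homo sapiens) for inhibition (a higher number here means a weaker inhibitor, a lower number a stronger inhibitor), compound 1 gives 4 nM. Going by the values given here, this is the only numerical value in the set; the other entry is a limit. Compound 2 `CCOc1nc(N)nc2ncc(-c3ccc(OC)cc3)nc12` is reported in this assay only as a limit, > 10000 nM, and the limit of > 10000 nM in this assay, at which 1 of the 2 values shown sits, marks where that entry sits. Among the compounds with values here, compound 2 differs from compound 1 in more than one place, so no single step between the two can be read; their values show only that compound 1 is a potent inhibitor while compound 2 gives no number within the window of this assay.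

Compound 3 `COc1ccc(-c2cnc3nc(N)nc(N4CCN(Cc5ccc(C(C)(C)C)cc5)CC4)c3n2)cc1OC` has not yet been measured. It differs from compound 1 by 4-(tert-butyl)benzyl in place of (phenoxymethyl)carbonyl on an amine nitrogen in a ring. Within the data shown here, no measured step bears on this change, so its size is unknown. The step of a 5.0-fold higher number from compound 1 to compound 3 (0.70 log units; beyond the scatter) is expected to be a modest weakening, somewhat beyond the scatter. For compound 3 in this assay the estimate is 20 nM, with a range from 3 nM to 150 nM.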

Compound 3, half-maximal inhibitory concentration: 4300 nM
Beside the measured number, compound 3's estimate is 220-fold (2.33 log units) below it, and the stated range ends below it.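

In this assay, the group on this amine nitrogen in a ring has a large effect on inhibition: with the shared core unchanged, 4-(tert-butyl)benzyl in place of (phenoxymethyl)carbonyl gives a 1100-fold higher number from compound 1 to compound 3 (3.03 log units; beyond the scatter). Compound 3 keeps a six-membered aromatic ring of carbon only on this nitrogen, as compound 1 does, so the presence of such a ring on this arm does not by itself preserve the potency of compound 1, and this position does not tolerate every large group. The group that leaves holds a carbonyl and hydrogen-bond acceptors and the group that enters holds neither, but no measurement shown here ties the loss to either difference or gives a reason for it.

Going by these compounds alone, the single step changes the carbonyl, the ether oxygen and the tert-butyl group together, so their separate contributions remain open. An unsubstituted benzyl group, a benzoyl group or a 4-(tert-butyl)phenoxyacetyl group on the same nitrogen would help separate the effect of the tert-butyl group from that of the carbonyl and the ether oxygen.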